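A Secondary Amine in Place of a Tertiary One

The compounds below may be only part of what the source reports. "The series", "measured", "known", "first", "only" and "open" are said of these compounds alone.

Measured so far:
compound 1, `Cc1nnc(CN(C)C)n1-c1ccc(Cl)cc1C(=O)c1ccccc1`: 5 mg/kg
compound 2, `Cc1nnc(CN2CCCC2)n1-c1ccc(Cl)cc1C(O)c1ccccc1`: > 25 mg/kg; > 200 mg/kg (2 entries)
compound 3, `CN(C)Cc1nccn1-c1ccc(Cl)cc1C(=O)c1ccccc1Cl`: 11 mg/kg

In a functional assay on the whole organism (strain CF-1) with Mus musculus as the target (on this read-out lower numbers stand for an effect already at smaller amounts and higher numbers for an effect only at larger amounts of compound), compound 1 gives 5 mg/kg. Compound 3 gives 11 mg/kg, a higher number, and the gap between the two lies beyond the scatter. Compound 2 returns only limits of the assay rather than numbers, shown by the several entries of compound 2 in this assay, > 25 mg/kg; > 200 mg/kg (2 entries). Compound 1 thus carries the lowest of the two numbers recorded in this assay, with compound 3 nearest to it.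

The unmeasured compound 4, `CCNCc1nnc(C)n1-c1ccc(Cl)cc1C(=O)c1ccccc1`, keeps the whole core of compound 1 and the ketone and differs from it in a single place: ethylamino in place of dimethylamino on a saturated chain carbon bound to an aromatic carbon. A tertiary amine thus becomes a secondary one, and the two compounds hold the same atoms joined differently. Among the measured compounds shown here, none of the measured pairs isolates this kind of change, so no measured step sets its size; the spread from compound 1 to compound 3 only shows how much the numbers here can move between close relatives.

The change is expected to be small, at most a slight move toward a higher number, and likely to stay within the scatter as a 1.4-fold higher number from compound 1 to compound 4 (0.15 log units; within the scatter). Compound 4 is therefore estimated at 7 mg/kg, in a range from 2.5 mg/kg to 20 mg/kg.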

Compound 4, dose for half-maximal effect: 2.5 mg/kg
Compound 4: the middle estimate sits 2.8-fold (0.45 log units) above what was measured; measured number inside the range.
By their numbers in this assay, from the lowest: compounds 4 and 1 (each within the scatter of the next); then compound 3.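

In this assay, ethylamino in place of dimethylamino on a saturated chain carbon bound to an aromatic carbon gives a 2.0-fold lower number from compound 1 to compound 4 (0.30 log units; within the scatter), so this read-out cannot tell the two compounds apart. Among the compounds shown here, this is the first measured step at this place, and it shows that a secondary amine, which brings one hydrogen-bond donor where the tertiary amine had none, keeps the effect at small doses in the whole animal, even though the atoms are joined differently. The compounds shown offer no explanation for this result, so the step stands as an observation about this one pair and this one core.

From the compounds shown here alone, one pair says little about how far the amine can be varied at this place, so it remains open whether a primary amine, or a longer chain on the nitrogen such as propylamino, would also stay close to compound 1. Going by these compounds, it also remains open whether ethylamino would behave in the same way on the core of compound 3, which carries dimethylamino at the matching place.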